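Succinimide amides: ethyl homologue of compound 3

This account rests on a few compounds, and the source may have more. Where it says the series, first, only, none or still open, it means among the compounds named here.

Measured so far, all in a functional assay on the whole organism (strain Swiss) with Mus musculus as the target, in the maximal electroshock model, with a stated time of 0.25 h, at a dose of 300 mg/kg by the intraperitoneal route; a lower number here means a weaker effect, a higher number a stronger effect of the compound at the dose given: compound 1 `CCC(C(=O)N1CCN(c2ccccc2Cl)CC1)N1C(=O)CCC1=O` gives 50%; compound 2 `CCC(C(=O)N1CCN(c2ccccc2F)CC1)N1C(=O)CCC1=O` gives 100%; compound 3 `CC(C(=O)N1CCN(c2ccccc2C(F)(F)F)CC1)N1C(=O)CCC1=O` gives 100%.

Compound 3 stands level with compound 2 at the digits printed, the two together the highest of the three, and beyond the scatter from compound 1. Among the compounds with values here, the only single-point step known is a number 50 percentage points higher from compound 1 to compound 2 (beyond the scatter), a change on an aromatic carbon. Compound 4 `CCC(C(=O)N1CCN(c2ccccc2C(F)(F)F)CC1)N1C(=O)CCC1=O` differs from compound 3 by methyl in place of hydrogen on a saturated chain carbon, two bonds along the chain from an amide-type nitrogen in a ring and a carbonyl carbon. Within the data shown here, no measured step tests this chain change on its own; compound 2 and compound 3 differ in two places, yet both reach the top of the scale. Since compound 3 already sits at the ceiling, the step is expected to be a number 5 percentage points lower from compound 3 to compound 4 (within the scatter). Compound 4 is therefore estimated at 95%, between 65% and 100%.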

Compound 4, a percentage reported as activity, at one dose (the size of the read-out at that dose, not a potency): 25%
Compound 4: middle estimate off by 70 percentage points, on the high side; the measured number lies below the stated range.
By their numbers in this assay, from the lowest: compound 4; then compound 1; then compounds 2 and 3 (each within the scatter of the next).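

In this assay the chain carbon proves far from silent: with trifluoromethyl held fixed, methyl to ethyl gives a number 75 percentage points lower from compound 3 to compound 4 (beyond the scatter). With the ethyl chain held fixed, the aromatic carbon is equally sensitive, as trifluoromethyl in place of fluoro gives a number 75 percentage points lower from compound 2 to compound 4 (beyond the scatter) and trifluoromethyl in place of chloro gives a number 25 percentage points lower from compound 1 to compound 4 (beyond the scatter). Nothing at hand bears on the reason for these steps.

Still open, going by these compounds, is whether the chain step holds with fluoro or chloro on the aromatic carbon. Also open, on these data alone, is how a longer chain such as propyl would read at this chain carbon.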